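The source may hold more compounds than are shown below. What is called first, only, known or untested is meant among the compounds shown, and "the series" means these compounds.

Three compounds share one core and differ only in the group attached to a carbonyl carbon. Compound 1 `CCCNC(=O)Nc1cc2nc(C3CCCCC3)[nH]c2cc1N1CCCC1` carries a propylamino group there, compound 2 `Cc1ccc(C(=O)Nc2cc3nc(C4CCCCC4)[nH]c3cc2N2CCCC2)cc1` a 4-methylphenyl group, and compound 3 `CCCOCC(=O)Nc1cc2nc(C3CCCCC3)[nH]c2cc1N1CCCC1` a propoxymethyl group. In an ADME assay on Vero cells (Chlorocebus sabaeus) for cytotoxicity, read by resazurin assay, with a stated time of 3 days (on this read-out higher numbers stand for weaker inhibition and lower numbers for stronger inhibition), compound 1 gives > 100 ug/mL, a limit of the assay rather than a number. In this assay compound 2 gives > 100 ug/mL, also a limit. In this assay compound 3 gives > 100 ug/mL, again a limit. Because all three sit at the limit of > 100 ug/mL in this assay, at which 3 of the 3 values shown sit, the steps a step that the two limits leave unreadable from compound 1 to compound 2, a step that the two limits leave unreadable from compound 1 to compound 3 and a step that the two limits leave unreadable from compound 2 to compound 3 cannot be sized. Compound 4 `CCOCCOC(=O)Nc1cc2nc(C3CCCCC3)[nH]c2cc1N1CCCC1` differs from compound 3 by 2-ethoxyethoxy in place of propoxymethyl on a carbonyl carbon. For the measured compounds named here, the measured steps show only that changes at this carbonyl carbon have not moved any value off the limit. Compound 4 is therefore expected to show a step that the limit leaves unreadable from compound 3 to compound 4, with an estimate of 150 ug/mL, between 80 ug/mL and 400 ug/mL.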

Compound 4, half-maximal inhibitory concentration: > 100 ug/mL
Compound 4 gave a limit, no number; the forecaster's own chance of this, stated with the estimate: 85%; the middle value lies beyond the limit too.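

No step can be read between compound 4 and compound 1, compound 2 or compound 3, because in this assay all four give only a limit, not a number: the limit of > 100 ug/mL in this assay, at which 4 of the 4 values shown sit. How strongly any of these compounds inhibits in this assay stays open, and so does whether the groups on the carbonyl carbon differ at all.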